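The compounds below may be only part of what the source reports. "The series", "measured", "known", "first", "only" and "open" are said of these compounds alone.

Going by the values given here, compound 1, with the structure `NC(=O)c1c(NC(=O)c2ccccc2Cl)sc2c1CCN(Cc1ccccc1Cl)C2`, is the one compound here that gives an actual number: in a functional assay on HeLa cells (Homo sapiens) for antiproliferative activity, with a stated time of 24 h (on this read-out lower numbers stand for stronger inhibition and higher numbers for weaker inhibition), compound 1 gives 27500 nM. The other measured compound, compound 2, with the structure `NC(=O)c1c(NC(=O)c2ccccc2Cl)sc2c1CCN(C(=S)Nc1ccc(C(F)(F)F)cc1)C2`, reaches only a limit of the assay. In this assay compound 2 gives > 50000 nM, a limit and not a number. Thus the two measured compounds differ in more than one place, and no single step between them can be separated out; what they show is that one compound sits at the limit of > 50000 nM in this assay, at which 1 of the 2 values shown sits, while the other sits close to it.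

Compound 3, with the structure `NC(=O)c1c(NC(=O)c2ccccc2Cl)sc2c1CCN(C(=O)Nc1c(Cl)cccc1Cl)C2`, has not yet been measured. It differs from compound 1 in one place: (2,6-dichlorophenyl)carbamoyl in place of 2-chlorobenzyl on an amine nitrogen in a ring. This group brings a hydrogen-bond donor and a hydrogen-bond acceptor where compound 1 carries neither, and it sits on the same amine nitrogen in a ring where compound 2 carries its own substituted group. Given that compound 2 reaches only the limit, compound 3 is expected to stay weak, with an expected step from compound 1 to compound 3 of a 1.5-fold higher number from compound 1 to compound 3 (0.16 log units; within the scatter), no larger than the scatter or leaning toward weaker. In this assay compound 3 is estimated at 40000 nM, expected between 15000 nM and 100000 nM.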

Compound 3, half-maximal inhibitory concentration: 27200 nM
Beside the measured number, compound 3's estimate is 1.5-fold (0.17 log units) above it, within the range that was stated.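

Going by these compounds alone, the change gives a 1.0-fold lower number from compound 1 to compound 3 (0.00 log units; within the scatter), the first step that can be read at this position, so in this assay the two groups cannot be told apart. The amine nitrogen in a ring can therefore carry (2,6-dichlorophenyl)carbamoyl, with its hydrogen-bond donor and hydrogen-bond acceptor, in place of 2-chlorobenzyl, which has neither, and the number stays within the scatter; adding these features here does not by itself take a compound to the limit of the assay. Nothing measured here gives a reason why the two groups match, and no cause can be assigned.

Within the data shown here, what remains open is whether anything placed on this nitrogen can move the number beyond the scatter, since the one step read here shows no difference and cannot indicate which direction would give stronger inhibition. A simple alkyl amine, a carboxylic acid or a longer carbon chain at this position would test this, as would replacing the chlorine atoms on the aromatic ring of the carbamoyl group with hydrogen, which would show whether those atoms matter at all.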